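The source may hold more compounds than are shown below. What is called first, only, known or untested is meant among the compounds shown, and "the series" means these compounds.

Of the compounds shown here, two have been tested so far in a functional assay on A549 cells (Homo sapiens) for inhibition, tested at 10 uM; on this read-out higher numbers stand for a stronger effect at the one concentration tested and lower numbers for a weaker effect. Compound 1 `Cc1ccc(S(=O)(=O)n2cc(-c3cc(C(F)(F)F)ccn3)c3cc(OCc4ccccc4)ccc32)cc1` gives 9.9% in this assay. Compound 2 `COc1ccc2c(c1)c(-c1cc(C(F)(F)F)c(C#N)c(-c3cn(S(=O)(=O)c4ccc(C)cc4)c4ccc(OC)cc34)n1)cn2S(=O)(=O)c1ccc(C)cc1`, a larger molecule carrying a cyano group, gives 25.2% in this assay, the higher of the two numbers and beyond the usual scatter from compound 1.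

Compound 3 `COc1ccc2c(c1)c(-c1cc(C(F)(F)F)cc(-c3cn(S(=O)(=O)c4ccc(C)cc4)c4ccc(OC)cc34)n1)cn2S(=O)(=O)c1ccc(C)cc1` has not yet been measured. It differs from compound 2 in one place: hydrogen in place of cyano on an aromatic carbon, with the cyano sitting on an aromatic carbon of a six-membered aromatic ring with one nitrogen.

Going by the values given here, no measured pair shows what removing a cyano group does here, so the expectation rests on the size of the change alone: a small group leaves and a hydrogen enters. A modest fall in this assay, or none beyond the scatter, is expected, the estimated step from compound 2 to compound 3 being a number 7.2 percentage points lower from compound 2 to compound 3 (within the scatter). Compound 3 is therefore estimated at 18%, expected to lie between 5% and 32%.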

Compound 3, a percentage reported as inhibition, at one concentration (the size of the read-out at that concentration, not a potency): 22.2%
Estimate against measurement, compound 3: 4.2 percentage points below, within the range that was stated.
By their numbers in this assay, from the lowest: compound 1; then compounds 3 and 2 (each within the scatter of the next).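

In this assay, replacing the cyano on this aromatic carbon with hydrogen gives a number 3 percentage points lower from compound 2 to compound 3 (within the scatter). At this position, ortho to a trifluoromethyl group, the two heavy atoms of the cyano group are therefore not required for the effect seen at the one concentration tested, and this read-out cannot tell compound 2 and compound 3 apart. Nothing measured here explains why the swap leaves the number within the scatter.

From the compounds shown here alone, only cyano and hydrogen can be compared at this carbon, so it remains open whether an amine or a carboxylic acid placed there would give a number beyond the scatter from compound 3. A single-concentration read-out also leaves open whether compound 2 and compound 3 would match in potency.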